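Swapping the ester group on compound 3's cyclohexyl carbamate core

The source may hold more compounds than are shown below. What is called first, only, known or untested is meant among the compounds shown, and "the series" means these compounds.

Of the compounds shown here, three sharing one core have been measured so far. Compound 1 `COc1ccc(C(=O)OC2(C(=O)Nc3ccc([N+](=O)[O-])cc3)CCCCC2)cc1` carries a 4-methoxyphenyl on the ester carbonyl carbon, compound 2 `O=COC1(C(=O)Nc2ccc([N+](=O)[O-])cc2)CCCCC1` a hydrogen there, and compound 3 `CC(=O)OC1(C(=O)Nc2ccc([N+](=O)[O-])cc2)CCCCC1` a methyl. In a functional assay on MCF7 cells (Homo sapiens) for inhibition, read by MTT assay, with a stated time of 72 h (a higher number here means a weaker inhibitor, a lower number a stronger inhibitor), compound 1 gives 41.2 nM, compound 2 gives 35.4 nM, and compound 3 gives 403 nM. Compound 3 thus shows the highest number of the three, meaning the weakest inhibition; the gap between compound 1 and compound 2 is a 1.2-fold lower number from compound 1 to compound 2 (0.07 log units; within the scatter), so those two cannot be told apart.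

Compound 4 `CC(=O)Oc1ccccc1C(=O)OC1(C(=O)Nc2ccc([N+](=O)[O-])cc2)CCCCC1` is not yet measured. It differs from compound 3 by 2-acetoxyphenyl in place of methyl on a carbonyl carbon. Two measured steps speak to this change: the move from an aromatic ring to methyl gave a 9.8-fold higher number from compound 1 to compound 3 (0.99 log units; beyond the scatter), and the move from hydrogen to methyl gave an 11-fold higher number from compound 2 to compound 3 (1.06 log units; beyond the scatter). Replacing the methyl with an aromatic ring again is the reverse of the first of these steps, so a lower number, on the order of that step, is expected for compound 4.

Compound 4 is therefore estimated at 50 nM in this assay, with a plausible range from 15 nM to 200 nM, an expected step of an 8.1-fold lower number from compound 3 to compound 4 (0.91 log units; beyond the scatter).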

Compound 4, half-maximal inhibitory concentration: 16.9 nM
Compound 4: the middle estimate sits 3.0-fold (0.47 log units) above what was measured; the range from low to high includes it.
By their numbers in this assay, from the lowest: compound 4; then compounds 2 and 1 (each within the scatter of the next); then compound 3.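

On a carbonyl carbon of the ester, putting 2-acetoxyphenyl where compound 3 has methyl gives a 24-fold lower number from compound 3 to compound 4 (1.38 log units; beyond the scatter) in this assay and shows that the shared core can reach low numbers with a large group at this carbon. The same group also gives a 2.1-fold lower number from compound 2 to compound 4 (0.32 log units; beyond the scatter) and a 2.4-fold lower number from compound 1 to compound 4 (0.39 log units; beyond the scatter) as modest steps, which makes compound 4 the strongest inhibitor of the four and shows that the number still moves when one aromatic group replaces another. Both aromatic groups give lower numbers than methyl, but a ring is not required for this, as compound 2 goes against that pattern with only a hydrogen at this carbon.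

The compounds shown leave open whether the acetoxy group itself matters, which a plain phenyl group at this carbon would test, and whether an amine or a carboxylic acid on the ring would be tolerated. A longer chain such as ethyl or propyl would show whether the high number belongs to methyl alone or to small alkyl chains in general. Nothing shown here gives a measured reason for any of these differences.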